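The compounds below may be only part of what the source reports. "The series", "measured", "known", "first", "only" and "open" are said of these compounds alone.

Measured in an ADME assay on Raji cells (Homo sapiens) for cytotoxicity, read by luminescence, with a stated time of 72 h; a higher number here means that more compound is needed for the effect, a lower number that less compound is needed:
- compound 1 `CCOC(=O)c1c(-c2cccc(Oc3ccccc3)c2)[nH]c2cc(OC)c(F)cc2c1=O`: > 21500 nM, a limit
- compound 2 `CCOC(=O)c1c(-c2cccc(Br)c2)[nH]c2cc(OC)c(F)cc2c1=O`: > 21500 nM, a limit
- compound 3 `CCOC(=O)c1c(-c2cccc(Cc3nc(C)c(C)s3)c2)[nH]c2cc(OC)c(F)cc2c1=O`: > 21500 nM, a limit

Compound 1 gives no number, only a limit, and the same holds for the other two: the limit of > 21500 nM in this assay, at which 3 of the 3 values shown sit. Compound 4 `COc1cc2[nH]c(-c3cccc(Oc4ccccc4)c3)c(C(=O)NCCN3CCCC3)c(=O)c2cc1F` is the next to be read, and it differs from compound 1 by (2-(pyrrolidin-1-yl)ethyl)amino in place of ethoxy on a carbonyl carbon. In words, (2-(pyrrolidin-1-yl)ethyl)amino stands in place of ethoxy on a carbonyl carbon.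

The measured steps are a step that the two limits leave unreadable from compound 1 to compound 2, a step that the two limits leave unreadable from compound 1 to compound 3 and a step that the two limits leave unreadable from compound 2 to compound 3. All three exchange a group on an aromatic carbon and keep the ethoxy, so none tests this change and none has a readable size. Going by the values given here, the only anchor for compound 4 is therefore the limit of compound 1, which stands at > 21500 nM.

A new group on the carbonyl carbon leaves room for movement in this assay, but the direction is only tentatively expected to be towards less compound needed, and another limit reading is quite possible. The expected step is an at least 1.4-fold lower number from compound 1 to compound 4 (0.15 log units; that floor lies within the scatter). For compound 4 the estimate is 15000 nM, with an expected range of 3000 nM to 40000 nM.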

Compound 4, half-maximal effective concentration: > 21500 nM
Compound 4 was reported as a limit (the forecaster's own chance of this, stated with the estimate: 55%); middle value at least 1.4-fold (0.15 log units) from the limit.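

Compound 1 and compound 4 are both limits in this assay, so the step between them cannot be read: the limit of > 21500 nM in this assay, at which 4 of the 4 values shown sit.

The compounds shown leave open how far any exchange, on the aromatic carbon or on the carbonyl carbon, shifts the number in this assay.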